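A few compounds are considered here, and "the series" means these few. Any claim that something is new, unique, unknown or untested is made for them only; others in the source may bear on it.

Compound 2 `CCOC(=O)c1ccc(NC(=O)N2CC2C#N)cc1` is a urea whose aromatic ring carries an ethoxycarbonyl group. In a functional assay on WiDr cells (Homo sapiens) for inhibition (on this read-out lower numbers stand for stronger inhibition and higher numbers for weaker inhibition), compound 2 gives 2500 nM. For the measured compounds named here, the only comparison available is compound 1 `N#CC1CN1C(=O)Nc1ccc(F)cc1`, which in this assay gives 2100 nM; the step of a 1.2-fold higher number from compound 1 to compound 2 (0.08 log units; within the scatter) is within the scatter, so the two stand side by side rather than apart. Compound 3 `N#CC1CN1C(=O)Nc1ccc([N+](=O)[O-])cc1` differs from compound 2 by nitro in place of ethoxycarbonyl on an aromatic carbon. Going by the values given here, since the one measured exchange at this position moved the number by a 1.2-fold higher number from compound 1 to compound 2 (0.08 log units; within the scatter), no step beyond the scatter is expected for compound 3, whose estimated result in this assay is 2500 nM, ranging from 1000 nM to 6300 nM, a step of no change at the digits printed from compound 2 to compound 3 (within the scatter).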

Compound 3, half-maximal inhibitory concentration: 4300 nM
For compound 3 the middle estimate is 1.7-fold (0.24 log units) below the measured one; low and high end bracket the measured number.
By their numbers in this assay, from the lowest: compounds 1, 2 and 3 (each within the scatter of the next, the first and the last beyond it).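

In this assay, for the compounds shown here, nitro in place of ethoxycarbonyl gives a 1.7-fold higher number from compound 2 to compound 3 (0.24 log units; within the scatter) and so leaves the two compounds level, whereas nitro in place of fluoro gives a 2.0-fold higher number from compound 1 to compound 3 (0.31 log units; beyond the scatter) and is the first exchange at this position to pass the scatter, though only modestly. Each neighbouring pair among the three groups thus stays within the scatter, and only fluoro and nitro stand apart. Nothing available explains this small separation.

The compounds shown leave open whether an amine, a carboxylic acid or a longer chain at this position would move the number further, in either direction.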